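This account rests on a few compounds, and the source may have more. Where it says the series, first, only, none or still open, it means among the compounds named here.

Measured so far:
Compound 1, `CCSc1nnc(-c2cc(OC)c(OC)c(OC)c2)n1-c1ccc(OC)cc1`: in a functional assay on HT-29 cells (Homo sapiens) for inhibition, read by MTT assay, with a stated time of 48 h (on this read-out higher numbers stand for weaker inhibition and lower numbers for stronger inhibition), compound 1 reaches only the assay limit of > 60000 nM, a limit and not a number.
Compound 2, `COc1ccc(-n2c(SCc3ccc(C)cc3)nnc2-c2cc(OC)c(OC)c(OC)c2)cc1`: in this assay compound 2 likewise reaches only the limit of > 60000 nM, again a limit and not a number.

Compound 2 therefore stands nowhere on a numbered scale in this assay; both values shown are limits. Within the data shown here, the one step that touches it, a step that the two limits leave unreadable from compound 1 to compound 2, cannot be sized because of the limit of > 60000 nM in this assay, at which 2 of the 2 values shown sit.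

Compound 3, `COc1ccc(-n2c(SCC(=O)c3ccc4ccccc4c3)nnc2-c2cc(OC)c(OC)c(OC)c2)cc1`, differs from compound 2 in one place: (naphthalen-2-yl)carbonyl in place of 4-methylphenyl on a saturated chain carbon bound to a sulfur.

Among the measured compounds shown here, no measured step with a readable size bears on this change; the only step is the unreadable one from compound 1 to compound 2. The expectation for compound 3 in this assay therefore rests on the limit alone, and no step beyond the scatter can be foreseen in either direction. Compound 3 is estimated at 60000 nM, with a range from 15000 nM to 200000 nM, most likely again reported only as a limit. The step from compound 2 to compound 3 that this estimate means is expected to be a number no higher from compound 2 to compound 3 (the limit leaves the size open).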

Compound 3, half-maximal inhibitory concentration: 53400 nM
Beside the measured number, compound 3's estimate is 1.1-fold (0.05 log units) above it, within the range that was stated.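

In this assay, among these compounds, compound 3 gives the first number, 53400 nM, which shows that this place on a saturated chain carbon bound to a sulfur can carry (naphthalen-2-yl)carbonyl and give a value that is not a limit, something neither earlier group did. The change from 4-methylphenyl reads as an at least 1.1-fold lower number from compound 2 to compound 3 (0.05 log units; that floor lies within the scatter), and the change from methyl reads as an at least 1.1-fold lower number from compound 1 to compound 3 (0.05 log units; that floor lies within the scatter); both are floors, and neither on its own shows a gain beyond the scatter. The full size of each step stays unknown because the starting compounds give no number to measure from: the limit of > 60000 nM in this assay, at which 2 of the 3 values shown sit.

The compounds shown leave open which part of the entering group matters, as the carbonyl and the naphthalen-2-yl enter together in compound 3, and either one alone on the same chain carbon would separate them. On these data alone, it also remains open whether an amine or a carboxylic acid at this place would carry the value clearly beyond the scatter from compound 3.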